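Cyclohexyl in place of chlorophenylethyl on the amide nitrogen

This account rests on a few compounds, and the source may have more. Where it says the series, first, only, none or still open, it means among the compounds named here.

compound 1 `COc1ncc(NC(=O)[C@H](C)[C@H]2CC[C@@H](c3ccnc4ccc(F)cc43)CC2)cn1` — 80 nM
compound 2 `C[C@H](NC(=O)[C@H](C)[C@H]1CC[C@@H](c2ccnc3ccc(F)cc32)CC1)c1ccc(Cl)cc1` — > 1000 nM

In an assay on blood for inhibition of Indoleamine 2,3-dioxygenase 1 (Homo sapiens), read by mass spectrometry, with stated times of 4 h and 18 h (a lower number here means a stronger inhibitor, a higher number a weaker inhibitor), compound 1 gives 80 nM. Compound 2 reaches only a limit of the assay, > 1000 nM. The single measured step, an at least 12-fold higher number from compound 1 to compound 2 (1.09 log units; beyond the scatter), rests on that limit (the limit of > 1000 nM in this assay, at which 1 of the 2 values shown sits), so compound 2 stands at the weak end of the numbers shown. Compound 3 `C[C@@H](C(=O)NC1CCCCC1)[C@H]1CC[C@@H](c2ccnc3ccc(F)cc32)CC1` differs from compound 2 by cyclohexyl in place of 1-(4-chlorophenyl)ethyl on an amide-type nitrogen. Among the measured compounds shown here, no measured step covers a change of this kind, so the expected step that the limit leaves unreadable from compound 2 to compound 3 is taken as none beyond the scatter. Compound 3 is therefore estimated at 1500 nM, within 300 nM to 8000 nM, and the assay may again report only a limit.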

Compound 3, half-maximal inhibitory concentration: 470 nM
Estimate against measurement, compound 3: 3.2-fold (0.50 log units) above; the range from low to high includes it.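

In this assay, the amide-type nitrogen tolerates cyclohexyl better than 1-(4-chlorophenyl)ethyl, with an at least 2.1-fold lower number from compound 2 to compound 3 (0.32 log units; beyond the scatter). That step is only a lower bound on the change: the limit of > 1000 nM in this assay, at which 1 of the 3 values shown sits. Cyclohexyl does not match 2-methoxypyrimidin-5-yl, with a 5.9-fold higher number from compound 1 to compound 3 (0.77 log units; beyond the scatter), so among the three groups shown, 2-methoxypyrimidin-5-yl gives the lowest number at this position. The compounds shown leave open whether the gain with 2-methoxypyrimidin-5-yl depends on its methoxy group or on its ring nitrogens. A plain phenyl or a pyridinyl on this nitrogen would separate the two.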